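From a bare ring nitrogen to a difluorobenzyl arm

The source may hold more compounds than are shown below. What is called first, only, known or untested is meant among the compounds shown, and "the series" means these compounds.

Compound 1 `C=C1C(=O)O[C@H]2[C@H]1CC/C(COC(=O)Cn1cc(F)c(=O)[nH]c1=O)=C\CC[C@@]1(C)O[C@@H]21` was tested in a functional assay on Bel7402/5-FU cells (Homo sapiens) for antiproliferative activity, read by MTT assay, with a stated time of 72 h; on this read-out higher numbers stand for weaker inhibition and lower numbers for stronger inhibition. In this assay compound 1 gives only a limit, > 20000 nM, not a number. Compound 2 `C=C1C(=O)O[C@H]2[C@H]1CC/C(COC(=O)CCC(=O)NCCCCCCNC(=O)Cn1cc(F)c(=O)[nH]c1=O)=C\CC[C@@]1(C)O[C@@H]21` also gives only a limit in this assay, > 20000 nM. Compound 3 `C=C1C(=O)O[C@H]2[C@H]1CC/C(COC(=O)Cn1cc(F)c(=O)n(Cc3ccc(F)cc3)c1=O)=C\CC[C@@]1(C)O[C@@H]21`, by contrast, gives 1140 nM in this assay. The one measured step that joins two of these compounds in one place is an at least 17-fold lower number from compound 1 to compound 3 (1.24 log units; beyond the scatter), which carries the value from a limit to a number; the limit of > 20000 nM in this assay, at which 2 of the 3 values shown sit, is where compound 1 sits, so the true size of that step is open upward.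

Compound 4 `C=C1C(=O)O[C@H]2[C@H]1CC/C(COC(=O)Cn1cc(F)c(=O)n(Cc3ccc(F)cc3F)c1=O)=C\CC[C@@]1(C)O[C@@H]21` differs from compound 1 by 2,4-difluorobenzyl in place of hydrogen on an aromatic nitrogen. Within the data shown here, this is the same kind of change as the one from compound 1 to compound 3, with a 2,4-difluorobenzyl entering where compound 3 carries a 4-fluorobenzyl. Among the measured compounds shown here, the step of an at least 17-fold lower number from compound 1 to compound 3 (1.24 log units; beyond the scatter) is the only evidence that bears on it, and it is large and points toward stronger inhibition. A step of similar size, in the same direction, is therefore expected for compound 4, namely an at least 20-fold lower number from compound 1 to compound 4 (1.30 log units; beyond the scatter). Compound 4 is estimated at 1000 nM in this assay, with a range from 300 nM to 3500 nM.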

Compound 4, half-maximal inhibitory concentration: 5010 nM
Compound 4: middle estimate off by 5.0-fold (0.70 log units), on the low side, and the stated range ends below it.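

In this assay, a second benzyl arm on the same aromatic nitrogen also lowers the number, with an at least 3.9-fold lower number from compound 1 to compound 4 (0.60 log units; beyond the scatter), so the gain is not confined to the 4-fluorobenzyl of compound 3. The arm's own substitution also matters: fluoro in place of hydrogen on an aromatic carbon of the arm gives a 4.4-fold higher number from compound 3 to compound 4 (0.64 log units; beyond the scatter), so the two fluorinated arms are not interchangeable at this position. Compound 1 gives only a limit, so the full size of its step to compound 4 stays open upward, as it does for its step to compound 3: the limit of > 20000 nM in this assay, at which 2 of the 4 values shown sit.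

As far as these compounds go, it remains open whether plain benzyl, 2-fluorobenzyl or 4-chlorobenzyl on this nitrogen would fall nearer to compound 3 or to compound 4, and so whether the higher number of compound 4 follows from a second fluoro as such or from where it sits on the arm. Also open, from the compounds shown here alone, is whether an arm as small as methyl on this nitrogen would lower the number at all, or whether a longer chain between the benzyl and the nitrogen would keep the gain.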